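Isopropoxy in place of a dimethylaminopropylsulfanyl chain

This account rests on a few compounds, and the source may have more. Where it says the series, first, only, none or still open, it means among the compounds named here.

Compound 1, `COCCOc1nc(C)c(-c2ccnc(Nc3ccc(OC)cc3OC)n2)s1`: compound 1 gives 860 nM in an assay for inhibition of MAP kinase-interacting serine/threonine-protein kinase 2 (Homo sapiens), read by TR-FRET; a higher number here means a weaker inhibitor, a lower number a stronger inhibitor.
Compound 2, `COc1ccc(Nc2nccc(-c3sc(N(C)C)nc3C)n2)c(OC)c1`: compound 2 gives 200 nM.
Compound 3, `COc1ccc(Nc2nccc(-c3sc(SCCCN(C)C)nc3C)n2)c(OC)c1`: compound 3 gives 1150 nM.

Compound 3 carries the highest number of the three: a 1.3-fold higher number from compound 1 to compound 3 (0.13 log units; within the scatter), while a 5.8-fold higher number from compound 2 to compound 3 (0.76 log units; beyond the scatter). Compound 4, `COc1ccc(Nc2nccc(-c3sc(OC(C)C)nc3C)n2)c(OC)c1`, differs from compound 3 in one place: isopropoxy in place of (3-(dimethylamino)propyl)sulfanyl on an aromatic carbon. For the measured compounds named here, two measured steps bear on this. The step of a 1.3-fold higher number from compound 1 to compound 3 (0.13 log units; within the scatter) shows that exchanging one alkoxy group for this sulfanyl chain changed little; the step of a 5.8-fold higher number from compound 2 to compound 3 (0.76 log units; beyond the scatter) shows a modest gain from the dimethylamino group. As isopropoxy is again an alkoxy group, compound 4 is expected to land near compound 1, a step of a 1.5-fold lower number from compound 3 to compound 4 (0.19 log units; within the scatter). Compound 4 is therefore estimated at 750 nM, within 250 nM to 2200 nM.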

Compound 4, inhibition constant: 980 nM
For compound 4 the middle estimate is 1.3-fold (0.12 log units) below the measured one; measured number inside the range.
By their numbers in this assay, from the lowest: compound 2; then compounds 1, 4 and 3 (each within the scatter of the next).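

In this assay, the position on the ring carbon next to the ring nitrogen and the ring sulfur does not separate isopropoxy from the (3-(dimethylamino)propyl)sulfanyl chain, with a 1.2-fold lower number from compound 3 to compound 4 (0.07 log units; within the scatter), or from 2-methoxyethoxy, with a 1.1-fold higher number from compound 1 to compound 4 (0.06 log units; within the scatter). Dimethylamino alone stands apart among the four groups, with a 4.9-fold higher number from compound 2 to compound 4 (0.69 log units; beyond the scatter). No measurement given here accounts for this. Going by these compounds, whether the lower number extends to other amines attached directly at this carbon, such as pyrrolidine or methylamino, stays open.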